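A Second Fluorine on the Stilbene Core

The source may report more compounds than this note shows. Statements on the series, on what has been measured and on what is new or still open speak of the compounds shown alone.

Compound 1, `Fc1ccccc1/C=C/c1ccccc1`, gives 700 nM in an assay on HepG2 cells for activation of nuclear factor erythroid 2-related factor 2 (Homo sapiens), read by a luciferase reporter, with a stated time of 5 h (on this read-out lower numbers stand for an effect already at smaller amounts and higher numbers for an effect only at larger amounts of compound), the lowest of the three numbers measured. Compound 2, `Fc1ccccc1/C=C/c1ccc(Cl)cc1`, gives 1600 nM, and compound 3, `Oc1ccc(/C=C/c2ccccc2F)cc1`, gives 11400 nM. The step of a 2.3-fold higher number from compound 1 to compound 2 (0.36 log units; beyond the scatter) is modest, whereas a 16-fold higher number from compound 1 to compound 3 (1.21 log units; beyond the scatter) is large. Compound 4, `Fc1ccccc1/C=C/c1ccccc1F`, differs from compound 1 by fluoro in place of hydrogen on an aromatic carbon. Both measured changes from compound 1 raised the number in this assay, the chloro modestly and the hydroxy strongly, so a further change on the same ring is expected to raise the number rather than lower it, though fluoro brings only a single heavy atom. The expected step is a 1.4-fold higher number from compound 1 to compound 4 (0.15 log units; within the scatter), a modest rise or none beyond the scatter. Compound 4 is therefore estimated at 1000 nM, between 350 nM and 2800 nM.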

Compound 4, half-maximal effective concentration: 4300 nM
Compound 4: middle estimate off by 4.3-fold (0.63 log units), on the low side; measured number outside the range, above it.
By their numbers in this assay, from the lowest: compound 1; then compound 2; then compound 4; then compound 3.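

Fluoro on an aromatic carbon, ortho to a group of 9 heavy atoms, brings only 1 heavy atom and no hydrogen-bond donors or acceptors, yet in this assay it gives a 6.1-fold higher number from compound 1 to compound 4 (0.79 log units; beyond the scatter), so a change this small at this place moves the number beyond the scatter. All three changes from compound 1 now raise the number. Nothing available explains this rise.

The compounds shown leave open whether an amine or a methoxy group at this same place would also raise the number.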